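Iodo in Place of Acetoxy on the Chain Carbon

The source may report more compounds than this note shows. Statements on the series, on what has been measured and on what is new or still open speak of the compounds shown alone.

Measured so far:
compound 1, `CCCOCC1=CS(=O)(=O)c2ccccc2C1=O`: 99.9%
compound 2, `CC(=O)OCC1=CS(=O)(=O)c2ccccc2C1=O`: 99.5%

Within the data shown here, in a functional assay on the whole organism for inhibition, with Mus musculus as the target, at a dose of 10 mg/kg (a higher number here means more inhibition at the dose given (going by the name of the read-out), a lower number less inhibition), compound 2 gives 99.5%, the lower of the two numbers, yet the one step seen so far, a number 0.4 percentage points lower from compound 1 to compound 2 (within the scatter), lies within the scatter, so the two compounds cannot be told apart on this read-out. Both sit close to the top of the scale.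

Compound 3, `O=C1C(CI)=CS(=O)(=O)c2ccccc21`, has not yet been measured. Its change from compound 2 is iodo in place of acetoxy on a saturated chain carbon bound to a double-bonded ring carbon. Among the measured compounds shown here, no measured step involves a halogen, so there is no direct precedent for this change. For the measured compounds named here, the only guide is that swapping one oxygen-bound group for another, a number 0.4 percentage points lower from compound 1 to compound 2 (within the scatter), left the number essentially level near the top of the scale. On that basis compound 3 is expected to stay high, with a step of a number 7.5 percentage points lower from compound 2 to compound 3 (within the scatter) leaving room for some loss. Compound 3 is estimated at 92%, within a range from 65% to 100%.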

Compound 3, a percentage reported as inhibition, in the whole organism at one dose (the size of the read-out at that dose, not a potency): 98%
Compound 3: the middle estimate sits 6 percentage points below what was measured; measured number inside the range.
By their numbers in this assay, from the lowest: compounds 3, 2 and 1 (each within the scatter of the next).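

In this assay the change from acetoxymethyl to iodomethyl gives a number 1.5 percentage points lower from compound 2 to compound 3 (within the scatter) and a number 1.9 percentage points lower from compound 1 to compound 3 (within the scatter) on the same read-out, so the three compounds cannot be told apart. Until now this saturated chain carbon had carried only oxygen-bound groups; it now also carries an iodo group, a single iodine atom with no hydrogen-bond acceptors in place of the four heavy atoms of acetoxy, and the number still stays near the top of the scale. No supporting data explain why the read-out holds level across these groups.

From the compounds shown here alone, whether an amine or a carboxylic acid on the same chain carbon would also keep the number this high remains open. All three compounds sit so close to the top of the scale that any real differences among them may not show at this single dose.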